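A few compounds are considered here, and "the series" means these few. Any claim that something is new, unique, unknown or untested is made for them only; others in the source may bear on it.

The measured compounds:
compound 1, `CCCCCCCCCCCCNC(=O)[C@@H](NC(=O)/C=C/c1ccccc1)[C@@H](C)O` – in a functional assay on HepG2 cells (Homo sapiens) for cytotoxicity, read by MTT assay, with a stated time of 48 h (a lower number here means a stronger inhibitor, a higher number a weaker inhibitor), compound 1 gives > 200000 nM, a limit of the assay rather than a number.
compound 2, `C/C=C/C=C/C(=O)N[C@H](C(=O)NCCCCCCCCCCCC)[C@@H](C)O` – in this assay compound 2 gives > 400000 nM, again a limit rather than a number.
compound 3, `CCCCCCCCCCCCCCCCCCNC(=O)[C@@H](NC(=O)/C=C/c1ccccc1)[C@@H](C)O` – in this assay compound 3 gives 128000 nM.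

Compound 4, `C/C=C/C=C/C(=O)N[C@H](C(=O)NCCCCCCCCCCCCCCCCCC)[C@@H](C)O`, has not yet been measured. It differs from compound 3 by prop-1-en-1-yl in place of phenyl on a double-bonded chain carbon bound to a double-bonded chain carbon. The same change, (prop-1-en-1-yl in place of phenyl on a double-bonded chain carbon bound to a double-bonded chain carbon), has already been made once, where it gave a step that the two limits leave unreadable from compound 1 to compound 2. The two cores differ by hexyl in place of hydrogen on a saturated chain carbon, ten or more bonds along the chain from an amide-type nitrogen, a change that gave an at least 1.5-fold lower number from compound 1 to compound 3 (0.19 log units; that floor lies within the scatter). Since both compounds of the earlier pair sit at a limit in a step that the two limits leave unreadable from compound 1 to compound 2, no size can be carried over, and the expectation can only stay close to compound 3. The expected step is a 1.6-fold higher number from compound 3 to compound 4 (0.19 log units; within the scatter). Compound 4 is estimated at 200000 nM, between 80000 nM and 500000 nM, with a real chance that only a limit is reported.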

Compound 4, half-maximal inhibitory concentration: 284000 nM
Compound 4: the middle estimate sits 1.4-fold (0.15 log units) below what was measured; the measured number falls inside the stated range.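

In this assay, prop-1-en-1-yl in place of phenyl on the core of compound 3 gives a 2.2-fold higher number from compound 3 to compound 4 (0.35 log units; beyond the scatter). The same change on the core of compound 1 gives a step that cannot be read, as both compounds of that pair sit at a limit of the assay, so this series does not show whether the change keeps its size from one core to the other. Hexyl in place of hydrogen on the chain gives an at least 1.4-fold lower number from compound 2 to compound 4 (0.14 log units; that floor lies within the scatter), and this too is only a floor set by a limit.

As far as these compounds go, what an amine or a carboxylic acid in place of phenyl, or a longer chain, would do in this assay stays open.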